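Propylamide in Place of Cyclopropyl Ketone on Compound 3

This account rests on a few compounds, and the source may have more. Where it says the series, first, only, none or still open, it means among the compounds named here.

Measured compounds:
compound 1 `O=C(C1CC1)[C@H]1C[C@H]2CNC[C@H]2C1` — 120%
compound 2 `CNC(=O)[C@H]1C[C@H]2CNC[C@H]2C1` — "not determined" (no result reported)
compound 3 `O=C(C1CC1)[C@H]1C[C@@H]2CNC[C@@H](C2)C1` — 22%

In an assay on SHEP1 cells for agonist activity at Neuronal acetylcholine receptor; alpha4/beta2 (Homo sapiens), read by FLIPR and calcium flux (on this read-out higher numbers stand for larger maximal responses and lower numbers for smaller maximal responses), compound 1 gives 120%. Compound 2, which carries a methylamino group on the carbonyl carbon of the same core, gives in this assay "not determined" (no result reported). Compound 3, built on a larger saturated core, gives in this assay 22%. Among the two numbers shown, compound 3 stands lowest; the number for compound 1 lies far above it, a gap beyond the scatter. Compound 1 and compound 3 differ in more than one place, and no step between measured compounds that differ in a single place is shown.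

Compound 4 `CCCNC(=O)[C@H]1C[C@@H]2CNC[C@@H](C2)C1` keeps the core of compound 3 and differs from it in one place: propylamino in place of cyclopropyl on a carbonyl carbon. Going by the values given here, no step between measured compounds shows what such an exchange does in this assay, and compound 2, the only amide among the measured compounds, gives in this assay "not determined" (no result reported).

For compound 4 a step of about a number 3 percentage points higher from compound 3 to compound 4 (within the scatter) in this assay is expected, small and without a clear direction beyond the scatter. Among the compounds with values here, the expected value for compound 4 is therefore 25%, within a range from 5% to 70%, a wide range because the only anchor is compound 3 with 22%.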

Compound 4, largest response reached (Emax), in percent of the reference or control that the assay uses: 54%
Compound 4: middle estimate off by 29 percentage points, on the low side; the range from low to high includes it.
By their numbers in this assay, from the lowest: compound 3; then compound 4; then compound 1.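

On the shared core, propylamino in place of cyclopropyl on a carbonyl carbon brings a number 32 percentage points higher from compound 3 to compound 4 (beyond the scatter) in this assay and so shows that the response on this core depends on what this carbonyl carbon carries. The earlier compounds shown here could not show this: compound 1 and compound 3 differ in more than one place, and compound 2, the only other amide, has no number. Nothing available explains the size or direction of this step.

The compounds shown leave open whether methylamino, butylamino or dimethylamino on the same carbonyl carbon would give a higher or lower response on this core. They also leave open whether propylamino in place of cyclopropyl would bring a similar step on the core of compound 1.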